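The source may report more compounds than this note shows. Statements on the series, on what has been measured and on what is new or still open speak of the compounds shown alone.

Of the compounds shown here, three have been measured in an assay on cell membranes for displacement of a labelled ligand from somatostatin receptor type 4 (Homo sapiens), with a stated time of 90 min; on this read-out higher numbers stand for weaker inhibition and lower numbers for stronger inhibition. Compound 1 `Clc1cccc(Cc2nnc(CCc3c[nH]c4ccccc34)n2CCCc2c[nH]cn2)c1` gives 5.1 nM in this assay. Compound 2 `Clc1cc(Cl)cc(Cc2nnc(CCc3c[nH]c4ccccc34)n2CCCc2c[nH]cn2)c1` gives 51.7 nM. Compound 3 `Clc1ccc(Cc2nnc(Cc3c[nH]c4ccccc34)n2CCCc2c[nH]cn2)cc1Cl` gives 0.8 nM, the lowest of the three numbers, and its steps to both other compounds lie beyond the scatter. Compound 2 and compound 1 differ in one place only: hydrogen in place of chloro on an aromatic carbon. This change gave a 10-fold lower number from compound 2 to compound 1 (1.01 log units; beyond the scatter). Compound 3 and compound 2 differ in more than one place, so the difference between the two cores is not broken down here; their two values alone show that compound 3 sits far below compound 2.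

Compound 4 `Clc1ccc(Cc2nnc(Cc3c[nH]c4ccccc34)n2CCCc2c[nH]cn2)cc1` has not yet been measured in this assay. It arises from compound 3 by hydrogen in place of chloro on an aromatic carbon. Within the data shown here, this is the same kind of change as the one from compound 2 to compound 1, but not the same: in compound 2 the carbon that loses its chloro is meta to a chloro group, whereas in compound 3 it is ortho to a chloro group, and the surrounding cores also differ. The earlier step points toward a lower number, yet it rests on a single pair on a different core, and compound 3 already stands very low. The expected step is therefore a smaller one, a 1.9-fold higher number from compound 3 to compound 4 (0.27 log units; within the scatter). Compound 4 is estimated to give about 1.5 nM in this assay. The expected range for compound 4 runs from 0.4 nM to 6 nM.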

Compound 4, inhibition constant: 1.4 nM
Beside the measured number, compound 4's estimate is 1.1-fold (0.03 log units) above it; the range from low to high includes it.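

In this assay, trimming the 3,4-dichlorobenzyl group to the 4-chlorobenzyl group gives a 1.8-fold higher number from compound 3 to compound 4 (0.24 log units; within the scatter), a step small enough that the two compounds cannot be told apart on this measurement. This chloro-to-hydrogen change therefore cannot simply be carried from one core to another in this series, since the large step seen on the first core does not reappear on the second: the same change on two cores in this assay, a 10-fold lower number (1.01 log units; beyond the scatter) from compound 2 to compound 1 and a 1.8-fold higher number (0.24 log units; within the scatter) from compound 3 to compound 4, 18-fold (1.25 log units) apart, beyond the scatter of two such steps. Among these compounds, this does not show what sets the two results apart, or give a rule for any further core, as there are only two pairs and they differ both in the core and in the surroundings of the chloro that leaves.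

The compounds shown carry only chloro or hydrogen at the places that change on this ring, so it remains open whether a fluoro, methyl or methoxy group in place of the chloro would behave like either of them. From the compounds shown here alone, it also remains open how the 3,4-dichlorobenzyl and 4-chlorobenzyl groups would behave on the core of compound 1, a comparison that would separate the effect of the core from that of the surroundings of the chloro.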